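The source may hold more compounds than are shown below. What is called first, only, known or untested is meant among the compounds shown, and "the series" means these compounds.

Compound 1, `COc1cccc(-c2c(S(=O)(=O)c3ccc(OC)c(Cl)c3)cnc3cc(F)ccc23)c1`: 1.71 mL/min
Compound 2, `COc1ccc(S(=O)(=O)c2cnc3cc(F)ccc3c2-c2ccc(F)cc2)cc1Cl`: 1.29 mL/min
Compound 3, `COc1ccc(S(=O)(=O)c2cnc3cc(F)ccc3c2-c2cccc(F)c2)cc1Cl`: 2.08 mL/min

All three were tested in an ADME assay on microsomes from liver (Homo sapiens) for metabolic stability, tested at 2.5 uM; on this read-out higher numbers stand for fast clearance and lower numbers for slow clearance. Compound 2 differs from compound 1 in its core as follows: 4-fluorophenyl in place of 3-methoxyphenyl on an aromatic carbon. That change gave a 1.3-fold lower number from compound 1 to compound 2 (0.12 log units; within the scatter). Compound 3 differs from compound 1 in another way: fluoro in place of methoxy on an aromatic carbon. This change gave a 1.2-fold higher number from compound 1 to compound 3 (0.09 log units; within the scatter). Between the two remaining compounds the step is a 1.6-fold higher number from compound 2 to compound 3 (0.21 log units; within the scatter). All three numbers therefore sit within the usual scatter of one another, and none of the three can be called faster or slower cleared than the rest.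

Compound 4, `O=S(=O)(c1ccc(F)c(Cl)c1)c1cnc2cc(F)ccc2c1-c1ccc(F)cc1`, has not yet been measured. It differs from compound 2 in this way: fluoro in place of methoxy on an aromatic carbon. For the measured compounds named here, this is the same kind of change as the one from compound 1 to compound 3, but not the same: in compound 3 the fluoro sits meta to a large group, whereas in compound 4 it sits ortho to a chloro group and para to a large group. Compound 4 keeps the core of compound 2, which differs from the core of compound 1 as set out above.

Going by the values given here, the only measured example of this kind of change stayed within the scatter, so compound 4 is expected to stay close to compound 2. The expected step from compound 2 to compound 4 is a 1.2-fold higher number from compound 2 to compound 4 (0.07 log units; within the scatter), resting on compound 3 because a 1.2-fold higher number from compound 1 to compound 3 (0.09 log units; within the scatter). Compound 4 is thus estimated at 1.5 mL/min, with a likely range from 0.8 mL/min to 2.8 mL/min.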

Compound 4, intrinsic clearance in a liver preparation (reported as CLH), per the amount of preparation that the assay uses: 0.69 mL/min
Compound 4: middle estimate off by 2.2-fold (0.34 log units), on the high side; measured number below the stated range.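

In this assay, fluoro in place of methoxy on the core of compound 2, which turns 3-chloro-4-methoxyphenyl into 3-chloro-4-fluorophenyl, gives a 1.9-fold lower number from compound 2 to compound 4 (0.27 log units; within the scatter). Set beside the same kind of change on the core of compound 1, the two steps cannot be told apart: the same change on two cores in this assay, a 1.2-fold higher number (0.09 log units; within the scatter) from compound 1 to compound 3 and a 1.9-fold lower number (0.27 log units; within the scatter) from compound 2 to compound 4, 2.3-fold (0.36 log units) apart, within the scatter of two such steps. For the compounds shown here, this shows no sign that the core alters what the change does, but it does not prove that the change carries over unaltered: there are only two pairs, neither step lies beyond the scatter, the methoxy that leaves is not the same one in the two pairs, and a modest real difference between the cores would go unseen.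

The compounds shown leave open what other groups would do at the place ortho to a chloro group and para to a large group, for example a hydroxyl, an amine or a longer chain such as ethoxy. They also leave open whether a carboxylic acid or an amine on the other aromatic ring, in place of fluoro or methoxy, would move the number in this assay by more than the scatter.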